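The source may report more compounds than this note shows. Statements on the series, on what has been measured and on what is new or still open speak of the compounds shown alone.

Measured so far:
compound 1 `CC(C)C[C@H](N)C(=O)NS(=O)(=O)OC[C@H]1OC[C@@H](n2cnc3c(N)ncnc32)[C@H](O)[C@@H]1O`: 1000 nM
compound 2 `CC(C)C[C@H](N)C(=O)NS(=O)(=O)OC[C@H]1OC[C@@H](n2cnc3c(N)ncnc32)C[C@@H]1O`: 6800 nM
compound 3 `Nc1ncnc2c1ncn2[C@@H]1CO[C@H](COS(=O)(=O)NC(=O)[C@@H]2CCCN2)[C@@H](O)C1`: 2800 nM

In a functional assay on PBMC cells (Homo sapiens) for inhibition (a higher number here means a weaker inhibitor, a lower number a stronger inhibitor), compound 1 gives the lowest of the three numbers: compound 3 is the nearest to it and compound 2 the furthest. Two steps separate these compounds. Removing the hydroxy from a saturated ring carbon gave a 6.8-fold higher number from compound 1 to compound 2 (0.83 log units; beyond the scatter), and exchanging the amino-acid part of the molecule, pyrrolidin-2-yl in place of 1-amino-3-methylbutyl on the carbonyl carbon, gave a 2.4-fold lower number from compound 2 to compound 3 (0.39 log units; beyond the scatter).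

Compound 4 `N=C(N)NCCC[C@H](N)C(=O)NS(=O)(=O)OC[C@H]1OC[C@@H](n2cnc3c(N)ncnc32)[C@H](O)[C@@H]1O` keeps the core and both hydroxy groups of compound 1 and changes only the side chain: a group of 6 heavy atoms (3 carbon, 3 nitrogen; no ring) in place of a group of 3 heavy atoms (3 carbon; no ring), on a saturated chain carbon, two bonds along the chain from an amine nitrogen and a carbonyl carbon. The step from compound 2 to compound 3 is the one that bears on this, since it too alters the amino-acid part while leaving the core untouched, and its size was modest. A change of similar, modest size is therefore expected here, with the direction uncertain, so the estimate leans towards a somewhat higher number with a wide range. For compound 4 the expected step is a 2.5-fold higher number from compound 1 to compound 4 (0.40 log units; beyond the scatter), giving an estimate of 2500 nM with a range from 500 nM to 15000 nM.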

Compound 4, half-maximal inhibitory concentration: 600 nM
Compound 4: the middle estimate sits 4.2-fold (0.62 log units) above what was measured; low and high end bracket the measured number.
By their numbers in this assay, from the lowest: compounds 4 and 1 (each within the scatter of the next); then compound 3; then compound 2.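

In this assay, putting the larger nitrogen-rich group of compound 4 in place of the isopropyl of compound 1 gives a 1.7-fold lower number from compound 1 to compound 4 (0.22 log units; within the scatter) and so leaves the two compounds indistinguishable. The earlier steps had shown this assay responding to the ring hydroxy and to the whole amino-acid part, whereas this pair shows that the end of the side chain can go from a group with no hydrogen-bond donors to one with 3 without the number moving beyond the scatter. Nothing available explains this tolerance. Still open, from the compounds shown here alone, is how a carboxylic acid, an amine on a shorter chain or a phenyl ring would fare at this place. Also open, going by these compounds, is whether the same side chain would give a similar number on the core of compound 2, which lacks the ring hydroxy.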